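Replacing 4-acetamidophenyl with 3-methylphenyl

The source may hold more compounds than are shown below. What is called first, only, known or untested is meant among the compounds shown, and "the series" means these compounds.

Values in a functional assay on MDA-MB-231 cells (Homo sapiens) for cytotoxicity, read by MTT assay, with a stated time of 48 h; on this read-out lower numbers stand for stronger inhibition and higher numbers for weaker inhibition:
Compound 1 `O=C(OCCCC(c1ccc(F)cc1)c1ccc(F)cc1)c1cc(Cl)c(OCc2ccccc2)c(Cl)c1`: > 20000 nM, a limit
Compound 2 `O=C(NCCCCC(c1ccc(F)cc1)c1ccc(F)cc1)Nc1ccc([N+](=O)[O-])cc1`: 6470 nM
Compound 3 `CC(=O)Nc1ccc(NC(=O)NCCCCC(c2ccc(F)cc2)c2ccc(F)cc2)cc1`: > 20000 nM, a limit

Compound 3 sits at the limit of > 20000 nM in this assay, at which 2 of the 3 values shown sit, so it has a limit and no exact number. Compound 4 `Cc1cccc(NC(=O)NCCCCC(c2ccc(F)cc2)c2ccc(F)cc2)c1` carries 3-methylphenyl in place of 4-acetamidophenyl on an amide-type nitrogen. Going by the values given here, the one measured step that bears on this is an at least 3.0-fold higher number from compound 2 to compound 3 (0.49 log units; beyond the scatter), with acetamido in place of nitro on an aromatic carbon. Compound 2 has no acetamido group and gives 6470 nM, so a modest move towards lower numbers is expected in this assay, though one measured step is thin support. The expected step is an at least 1.8-fold lower number from compound 3 to compound 4 (0.25 log units; that floor lies within the scatter). For compound 4 the estimate is 11000 nM, with an expected range of 5000 nM to 20000 nM.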

Compound 4, half-maximal inhibitory concentration: > 20000 nM
Compound 4: only a limit was reported; the forecaster's own chance of this, stated with the estimate: 35%; middle value at least 1.8-fold (0.25 log units) from the limit.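

In this assay, 3-methylphenyl in place of 4-nitrophenyl on the amide-type nitrogen gives an at least 3.0-fold higher number from compound 2 to compound 4 (0.49 log units; beyond the scatter). Of the three groups shown at this place, only 4-nitrophenyl gives an exact value, so losing it does not require an acetamido group to push the result out of range. The step from compound 3 to compound 4 cannot be read, because both values are limits: the limit of > 20000 nM in this assay, at which 3 of the 4 values shown sit.

On these data alone, whether an amine or a carboxylic acid on this ring would stay near compound 2 or also reach the limit remains open. As far as these compounds go, how far compound 3 and compound 4 truly differ also remains open.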